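The source may hold more compounds than are shown below. What is called first, only, known or untested is meant among the compounds shown, and "the series" means these compounds.

Compound 1 `CC(C)c1onc(-c2c(Cl)cccc2Cl)c1COc1ccc(-c2nc3ccc(C(=O)O)cc3n2CC(C)(C)C)cc1`: 13 nM
Compound 2 `CC(C)c1onc(-c2c(Cl)cccc2Cl)c1COc1ccc(-c2nc3ccc(C(=O)O)cc3n2CC2CCCCC2)cc1`: 0.52 nM

In an assay on Huh-7 cells for agonist activity at Bile acid receptor (Homo sapiens), read by a luciferase reporter (a lower number here means that less compound is needed, a higher number that more compound is needed for the effect), compound 2 gives 0.52 nM, the lowest of the two numbers; compound 1 gives 13 nM. Compound 3 `CC(C)c1onc(-c2c(Cl)cccc2Cl)c1COc1ccc(-c2nc3ccc(C(=O)O)cc3n2C2CCCCC2)cc1` differs from compound 2 by cyclohexyl in place of cyclohexylmethyl on an aromatic nitrogen. Among the compounds with values here, the only measured step, a 25-fold lower number from compound 1 to compound 2 (1.40 log units; beyond the scatter), changed the group carried by the chain rather than the chain itself, so it bears only loosely on this change; it does show that this part of the molecule can shift the number strongly. Shortening the chain is a smaller change, so a modest rise a 2.9-fold higher number from compound 2 to compound 3 (0.46 log units; beyond the scatter) is expected. Compound 3 is estimated at 1.5 nM, within 0.3 nM to 8 nM.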

Compound 3, half-maximal effective concentration: 4.21 nM
Compound 3: the middle estimate sits 2.8-fold (0.45 log units) below what was measured, and the stated range covers the measured number.
By their numbers in this assay, from the lowest: compound 2; then compound 3; then compound 1.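

In this assay, cyclohexyl in place of cyclohexylmethyl on the aromatic nitrogen gives an 8.1-fold higher number from compound 2 to compound 3 (0.91 log units; beyond the scatter), so the carbon linking the ring to the nitrogen matters, not only the ring itself. Cyclohexyl in place of neopentyl still gives a 3.1-fold lower number from compound 1 to compound 3 (0.49 log units; beyond the scatter), so the ring attached directly keeps part of the gain seen with cyclohexylmethyl. On these data alone, whether a longer chain such as cyclohexylethyl, or a phenyl ring on the same one-carbon link, would lower the number further stays open. Nothing measured here explains these differences.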